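The source may hold more compounds than are shown below. What is called first, only, known or untested is meant among the compounds shown, and "the series" means these compounds.

Measured so far in a functional assay on OVCAR-5 cells (Homo sapiens) for inhibition, read by sulforhodamine B assay, with a stated time of 48 h (a higher number here means a weaker inhibitor of growth, a lower number a stronger inhibitor of growth), are two compounds.

- compound 1 `Cc1ccc(C2=NN(c3ccc(S(C)(=O)=O)cc3)C(=O)CC2)cc1` gives > 100000 nM (a limit)
- compound 2 `Cc1cc(O)ccc1C1=NN(c2ccc(S(C)(=O)=O)cc2)C(=O)CC1` gives > 100000 nM (a limit)

Compound 2 therefore has no number, only a limit. For the measured compounds named here, the series so far shows the limit of > 100000 nM in this assay, at which 2 of the 2 values shown sit, and nothing finer. Next comes compound 3 `CCc1ccc(C2=NN(c3ccc(S(C)(=O)=O)cc3)C(=O)CC2)cc1` with 4-ethylphenyl in place of 4-hydroxy-2-methylphenyl on a carbon with a double bond to nitrogen and the rest of the structure unchanged. Going by the values given here, the one measured step at this place is a step that the two limits leave unreadable from compound 1 to compound 2 and its size cannot be read. No measured size carries over to the new change, so no step beyond the scatter is expected in this assay here. Compound 3 is estimated at 100000 nM (expected range 40000 nM to 200000 nM) and a report as a bare limit is the likeliest outcome. The estimated change is a number no higher from compound 2 to compound 3 (the limit leaves the size open) and no more than that is expected from this pair.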

Compound 3, concentration for total growth inhibition: > 100000 nM
Compound 3: no number, only a limit; the forecaster's own chance of this, stated with the estimate: 85%; the middle value sits exactly at the limit.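

Compound 3 adds no readable step: its steps from compound 1 and from compound 2 cannot be read, and the series offers only this: the limit of > 100000 nM in this assay, at which 3 of the 3 values shown sit. The compounds shown leave open how far apart these three lie and whether any change at this place gives a measurable value.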